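This account rests on a few compounds, and the source may have more. Where it says the series, first, only, none or still open, it means among the compounds named here.

Working notes on the series. In a functional assay on PC-3 cells (Homo sapiens) for inhibition, read by sulforhodamine B assay, with a stated time of 48 h (a lower number here means a stronger inhibitor, a higher number a weaker inhibitor), compound 1 (`COc1cc2c(cc1CCC(C)C)C(=O)C[C@@H](c1ccc(O)cc1)O2`) gives 36300 nM, compound 2 (`COc1cc2c(cc1CC1OC1(C)C)C(=O)C[C@@H](c1ccc(O)cc1)O2`) gives 27400 nM and compound 3 (`COc1ccc([C@@H]2C/C(=N/OCc3cn(-c4ccccc4CO)nn3)c3cc(CC=C(C)C)c(OC)cc3O2)cc1`) gives 26600 nM. All three values lie within the usual scatter of one another, so compound 3 cannot be separated from compound 1 or compound 2 on these numbers.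

The next comparison is with compound 4 (`COc1ccc([C@@H]2C/C(=N/OCc3cn(-c4ccc(C(N)=O)cc4)nn3)c3cc(CC=C(C)C)c(OC)cc3O2)cc1`). The structural change is 4-carbamoylphenyl in place of 2-(hydroxymethyl)phenyl on an aromatic nitrogen of a five-membered aromatic ring with 3 nitrogen.

Among the measured compounds shown here, only one measured step is available, a 1.3-fold lower number from compound 1 to compound 2 (0.12 log units; within the scatter). It exchanges isobutyl for 3,3-dimethyloxiran-2-yl on a saturated chain carbon bound to an aromatic carbon, so it bears only indirectly on this change. For the measured compounds named here, no measured pair varies the group on the aromatic nitrogen. The data therefore give no direction for the change, and the estimate stays anchored on compound 3 at 26600 nM. In this assay, no step beyond the scatter is expected, and the estimated step is a 1.1-fold lower number from compound 3 to compound 4 (0.03 log units; within the scatter). The wide range reflects the lack of a direct precedent.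

For compound 4 the expected value is 25000 nM, with an estimated range from 11000 nM to 55000 nM.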

Compound 4, half-maximal inhibitory concentration: 16100 nM
Compound 4: the middle estimate sits 1.6-fold (0.19 log units) above what was measured, within the range that was stated.
By their numbers in this assay, from the lowest: compounds 4, 3, 2 and 1 (each within the scatter of the next, the first and the last beyond it).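

In this assay the group on the aromatic nitrogen of the five-membered ring now has a measured pair, and exchanging 2-(hydroxymethyl)phenyl for 4-carbamoylphenyl leaves the number within the scatter (a 1.7-fold lower number from compound 3 to compound 4 (0.22 log units; within the scatter)). This exchange alters the substituent and its numbered place on the phenyl ring together, while the counts of hydrogen-bond donors and acceptors stay the same, so the pair shows only that these two substituted phenyl groups cannot be told apart here, not that either feature alone has no effect. Nothing measured beyond the values themselves bears on this result, and no explanation can be offered for it.

The compounds shown leave open how 4-(hydroxymethyl)phenyl and 2-carbamoylphenyl would compare, and those two groups would separate the identity of the substituent from its place on the phenyl ring. They also leave open whether an unsubstituted phenyl, a phenyl bearing a carboxylic acid or an amine, or a plain methyl on the same aromatic nitrogen would give a step beyond the scatter from compound 3.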